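The source may hold more compounds than are shown below. What is called first, only, known or untested is meant among the compounds shown, and "the series" means these compounds.

In a functional assay on L02 cells (Homo sapiens) for inhibition, read by Griess assay, with stated times of 1 h and 24 h (on this read-out higher numbers stand for weaker inhibition and lower numbers for stronger inhibition), compound 1 (`CC(C)Nc1nc(/C=C/c2ccccc2)nc2ccsc12`) stands at a limit of the assay, > 1000000 nM. Compound 2 (`CNc1nc(/C=C/c2ccccc2)nc2ccsc12`) stands at a limit too, > 1000000 nM. Among the measured compounds shown here, compound 3 (`CNc1nc(/C=C/c2ccco2)nc2ccsc12`), at 811000 nM, therefore holds the only actual number. Compound 4 (`Clc1ccc(CNc2nc(/C=C/c3ccco3)nc3ccsc23)cc1`) differs from it by 4-chlorophenyl in place of hydrogen on a saturated chain carbon bound to a nitrogen on an aromatic ring, which turns methyl into 4-chlorobenzyl. The measured steps offer little guidance: the one at this nitrogen is a step that the two limits leave unreadable from compound 1 to compound 2, and the other, at a different place, is an at least 1.2-fold lower number from compound 2 to compound 3 (0.09 log units; that floor lies within the scatter). Little room remains upward from compound 3, given (the limit of > 1000000 nM in this assay, at which 2 of the 3 values shown sit), so a modest fall is expected, though only loosely. The expected change is a 2.7-fold lower number from compound 3 to compound 4 (0.43 log units; beyond the scatter). The estimate for compound 4 is 300000 nM, with an expected range of 50000 nM to 1000000 nM.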

Compound 4, half-maximal inhibitory concentration: > 1000000 nM
Compound 4 gave a limit, no number (the forecaster's own chance of this, stated with the estimate: 25%); at least 3.3-fold (0.52 log units) between middle value and limit.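

In this assay, 4-chlorophenyl in place of hydrogen on a saturated chain carbon bound to a nitrogen on an aromatic ring gives an at least 1.2-fold higher number from compound 3 to compound 4 (0.09 log units; that floor lies within the scatter). Among the compounds shown here, this is the only step at this nitrogen with a readable floor, and it shows no gain in inhibition from methyl to 4-chlorobenzyl, though its true size remains unknown. Compound 4 stands at a limit of the assay, not at a number: the limit of > 1000000 nM in this assay, at which 3 of the 4 values shown sit.

From the compounds shown here alone, whether a carboxylic acid or a morpholine in place of the 4-chlorophenyl would give a number inside the assay's range remains open. So does whether any group at this nitrogen can strengthen inhibition at all.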